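This account rests on a few compounds, and the source may have more. Where it says the series, first, only, none or still open, it means among the compounds named here.

For the measured compounds named here, compound 1, with structure `ClCc1ccc(Cn2cnc3c(Cl)ncnc32)cc1`, stands as the lower of the two numbers measured so far: in a functional assay on NCI-H460 cells (Homo sapiens) for cytotoxicity, read by sulforhodamine B assay, with a stated time of 48 h (a lower number here means a stronger inhibitor of growth, a higher number a weaker inhibitor of growth), compound 1 gives 1820 nM. Its nearest neighbour, compound 2, with structure `ClCc1cccc(Cn2cnc3c(Cl)nc(Cl)nc32)c1`, gives 6310 nM in this assay, a gap beyond the scatter. From compound 1 the account moves to compound 3, with structure `Nc1nc(Cl)c2ncn(Cc3ccc(CCl)cc3)c2n1`, which carries amino in place of hydrogen on an aromatic carbon on the core of compound 1. Going by the values given here, no pair of measured compounds shows this change, so its size is open; compound 3 is expected to sit near compound 1 or somewhat weaker, with a step from compound 1 to compound 3 estimated at a 1.4-fold higher number from compound 1 to compound 3 (0.14 log units; within the scatter) and a value expected at 2500 nM, in the range 800 nM to 8000 nM.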

Compound 3, concentration for total growth inhibition: 9950 nM
For compound 3 the middle estimate is 4.0-fold (0.60 log units) below the measured one; measured number outside the range, above it.
By their numbers in this assay, from the lowest: compound 1; then compounds 2 and 3 (each within the scatter of the next).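

In this assay, for the compounds shown here, the change gives the first reading of this position, the aromatic carbon between two ring nitrogen atoms: amino in place of hydrogen brings a 5.5-fold higher number from compound 1 to compound 3 (0.74 log units; beyond the scatter). The hydrogen of compound 1 is thus preferred to amino at this carbon, although this rests on a single pair. Nothing measured here accounts for the size of the step.

The compounds shown leave open whether a methylamino group or a hydroxyl group on this carbon would behave as amino does. They also leave open whether the step would hold with other groups elsewhere on the core.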